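Sulfonyl on the ring nitrogen of compound 2

The source may report more compounds than this note shows. Statements on the series, on what has been measured and on what is new or still open speak of the compounds shown alone.

compound 1 `Cc1ccc(-c2nn(-c3ccccc3)cc2-c2nc3ccccc3[nH]2)cc1`: 7260 nM
compound 2 `FC(F)(F)c1ccc(-c2nn(-c3ccccc3)cc2-c2nc3ccccc3[nH]2)cc1`: 6330 nM
compound 3 `COc1ccc(S(=O)(=O)n2c(-c3cn(-c4ccccc4)nc3-c3ccc(F)cc3)nc3ccccc32)cc1`: 530 nM

All three values come from a functional assay on MCF7 cells (Homo sapiens) for antiproliferative activity, read by MTT assay, with a stated time of 24 h; a lower number here means a stronger inhibitor, a higher number a weaker inhibitor. Compound 2 stands level with compound 1 within the scatter, and both stand well above compound 3.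

The next compound to be measured is compound 4 `O=S(=O)(c1ccc(F)cc1)n1c(-c2cn(-c3ccccc3)nc2-c2ccc(C(F)(F)F)cc2)nc2ccccc21`, reached from compound 2 by (4-fluorophenyl)sulfonyl in place of hydrogen on an aromatic nitrogen. In words, (4-fluorophenyl)sulfonyl takes the place of hydrogen on an aromatic nitrogen.

For the measured compounds named here, only one measured step exists, a 1.1-fold lower number from compound 1 to compound 2 (0.06 log units; within the scatter), with trifluoromethyl in place of methyl on an aromatic carbon. It lies within the scatter and does not touch the nitrogen, so it says little about this change beyond leaving compound 2 as a fair starting point.

The nearest evidence is compound 3, which also carries a sulfonyl group on that nitrogen and gives 530 nM, against compound 2 at 6330 nM. Going by the values given here, compound 3 differs from compound 2 in more than one place, and no measured pair isolates the nitrogen change, so only part of that gap can be relied on.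

A clear move to a lower number is therefore expected, somewhat smaller than that gap. The expected step is a 7.9-fold lower number from compound 2 to compound 4 (0.90 log units; beyond the scatter) in this assay. The estimated value for compound 4 is 800 nM, with an expected range of 250 nM to 2500 nM.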

Compound 4, half-maximal inhibitory concentration: 3120 nM
For compound 4 the middle estimate is 3.9-fold (0.59 log units) below the measured one, outside the stated range (above it).
By their numbers in this assay, from the lowest: compound 3; then compound 4; then compounds 2 and 1 (each within the scatter of the next).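

For the compounds shown here, with a 2.0-fold lower number from compound 2 to compound 4 (0.31 log units; beyond the scatter) in this assay, this is the first measured step that isolates a change on the aromatic nitrogen of the five-membered ring. That nitrogen bears (4-fluorophenyl)sulfonyl, a group with its own aromatic ring, in place of hydrogen, and the number moves down rather than up, so the position accepts a large substituent without a loss in this assay. The step lies just beyond the scatter and is modest, so this substitution alone, on the trifluoromethyl compound, gives only a small gain, and nothing available explains why the step has this size.

Compound 3 differs from compound 4 in more than one place, so no pair shown separates the sulfonyl aryl substituent from the aryl group on the shared core, and the origin of the lower number for compound 3 stays unassigned. Also open, as far as these compounds go, is whether the aromatic ring on the sulfonyl is needed at all: a methylsulfonyl or an acetyl group on the same nitrogen would test that, and an amine or a carboxylic acid on that ring would test how much change the aryl group tolerates.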